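Working notes: methoxy in place of chloro on compound 2

This account rests on a few compounds, and the source may have more. Where it says the series, first, only, none or still open, it means among the compounds named here.

Measured so far in an ADME assay on HepG2 cells (Homo sapiens) for cytotoxicity, with a stated time of 72 h; a lower number here means that less compound is needed, a higher number that more compound is needed for the effect:
compound 1 `Cc1cc(NC(=O)Nc2ccc(C(C)(C)C)cc2)c2ccccc2n1` gives 17000 nM here
compound 2 `Cc1cc(NC(=O)Nc2ccc(Cl)c(Cl)c2)c2ccccc2n1` gives 17000 nM here
compound 3 `CC(=O)c1ccc(NC(=O)Nc2cc(C)nc3ccccc23)cc1` gives 19000 nM here

In this assay compound 2 gives 17000 nM, level with compound 1 at the digits shown, and its gap to compound 3 lies within the scatter. Compound 4 `COc1ccc(NC(=O)Nc2cc(C)nc3ccccc23)cc1Cl` has not yet been measured. The change from compound 2 is methoxy in place of chloro on an aromatic carbon with methoxy in place of chloro on an aromatic carbon, ortho to a chloro group and para to a large group.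

Going by the values given here, no measured step makes this exchange, so the evidence is indirect. The closest guide is a 1.1-fold higher number from compound 1 to compound 3 (0.05 log units; within the scatter), with acetyl in place of tert-butyl on an aromatic carbon, and that step stays within the scatter. No step beyond the scatter is therefore expected in this assay, and no direction can be argued with confidence. The estimate amounts to an expected 1.1-fold higher number from compound 2 to compound 4 (0.05 log units; within the scatter) only. For compound 4 the estimated value is 19000 nM, with an expected range of 10000 nM to 38000 nM overall.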

Compound 4, half-maximal effective concentration: > 25000 nM
Compound 4 was reported as a limit (the forecaster's own chance of this, stated with the estimate: 10%); at least 1.3-fold (0.11 log units) between middle value and limit.
By their numbers in this assay, from the lowest: compounds 1, 2 and 3 (each within the scatter of the next). At a limit, above all of these: compound 4.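

In this assay, methoxy in place of chloro on an aromatic carbon, ortho to a chloro group and para to a large group, gives an at least 1.4-fold higher number from compound 2 to compound 4 (0.16 log units; that floor lies within the scatter). Compound 4 is reported only as a limit, not as a number: the limit of > 25000 nM in this assay, at which 1 of the 4 values shown sits. This is the only step shown in which a chloro group stays on the ring, and its floor does not separate the two compounds beyond the scatter, so the exchange has no measured size yet, although the true gap may be wider.

On these data alone, how far the true value of compound 4 lies past its limit remains open. Also open, as far as these compounds go, is whether an amine, a hydroxyl or a longer ether such as ethoxy at this place would give a readable value in this assay.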